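Amide side chain change on the 4-methoxyphenyl core

A few compounds are considered here, and "the series" means these few. Any claim that something is new, unique, unknown or untested is made for them only; others in the source may bear on it.

Compound 1 `C=CC(=O)Nc1cccc(Oc2nc(Nc3cccc(OC)c3)nc3c2CSCC3)c1` gives 10100 nM in a functional assay on A549 cells (Homo sapiens) for antiproliferative activity, read by MTT assay, with a stated time of 72 h; a lower number here means a stronger inhibitor, a higher number a weaker inhibitor. Compound 2 `C/C=C/C(=O)Nc1cccc(Oc2nc(Nc3cccc(OC)c3)nc3c2CSCC3)c1` gives 21100 nM in this assay; the change made there, (prop-1-en-1-yl in place of vinyl on a carbonyl carbon), produced a 2.1-fold higher number from compound 1 to compound 2 (0.32 log units; beyond the scatter). Compound 3 `C=CC(=O)Nc1cccc(Oc2nc(Nc3ccc(OC)cc3)nc3c2CSCC3)c1` gives 4220 nM in this assay, the lowest number of the three; its core differs from that of compound 1 by 4-methoxyphenyl in place of 3-methoxyphenyl on a nitrogen on an aromatic ring, and that step was a 2.4-fold lower number from compound 1 to compound 3 (0.38 log units; beyond the scatter). Compound 4 `C/C=C/C(=O)Nc1cccc(Oc2nc(Nc3ccc(OC)cc3)nc3c2CSCC3)c1` has not yet been measured; it differs from compound 3 by prop-1-en-1-yl in place of vinyl on a carbonyl carbon, the same change as that made from compound 1 to compound 2, at a place described in the same words. Resting on a 2.1-fold higher number from compound 1 to compound 2 (0.32 log units; beyond the scatter), the expected step in this assay is a 2.1-fold higher number from compound 3 to compound 4 (0.32 log units; beyond the scatter). Compound 4 is therefore estimated at 8900 nM in this assay, with a range from 4500 nM to 18000 nM.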

Compound 4, half-maximal inhibitory concentration: 22200 nM
Compound 4: middle estimate off by 2.5-fold (0.40 log units), on the low side; the measured number lies above the stated range.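

In this assay, prop-1-en-1-yl in place of vinyl on the carbonyl carbon gives a 5.3-fold higher number from compound 3 to compound 4 (0.72 log units; beyond the scatter), in the same direction as on the core of compound 1, and the two step sizes cannot be told apart: the same change on two cores in this assay, a 2.1-fold higher number (0.32 log units; beyond the scatter) from compound 1 to compound 2 and a 5.3-fold higher number (0.72 log units; beyond the scatter) from compound 3 to compound 4, 2.5-fold (0.40 log units) apart, within the scatter of two such steps. Putting 4-methoxyphenyl in place of 3-methoxyphenyl gives a 1.1-fold higher number from compound 2 to compound 4 (0.02 log units; within the scatter), with no gain on the prop-1-en-1-yl amide like that seen on the vinyl amide, yet these two steps also cannot be told apart: the same change on two cores in this assay, a 2.4-fold lower number (0.38 log units; beyond the scatter) from compound 1 to compound 3 and a 1.1-fold higher number (0.02 log units; within the scatter) from compound 2 to compound 4, 2.5-fold (0.40 log units) apart, within the scatter of two such steps. Two cores show that the direction of the amide change held in both cases, not that its size is fixed or that it extends to other cores.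

Open, on these data alone, is how other groups on the carbonyl carbon would behave, such as ethyl or a longer chain ending in an amine. Also open, as far as these compounds go, is whether other groups on the nitrogen-bound phenyl ring, such as a chlorine or a carboxylic acid, would follow the methoxy result.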